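Aryl swap on the piperazine nitrogen: from naphthyl to chlorophenyl

This account rests on a few compounds, and the source may have more. Where it says the series, first, only, none or still open, it means among the compounds named here.

The series shares one core, varied only in the aryl group on the ring nitrogen. Compound 1 `Nc1scc(CN2CCN(c3ccc([N+](=O)[O-])cc3)CC2)c1C(=O)c1ccc(Cl)cc1` carries 4-nitrophenyl there; in a functional assay on CHO cells with adenosine receptor A1 (Homo sapiens) as the target, read by cAMP accumulation and immunoassay, with a stated time of 6 min, tested at 0.01 uM (on this read-out higher numbers stand for a weaker effect at the one concentration tested and lower numbers for a stronger effect), compound 1 gives -12%. Compound 2 `Nc1scc(CN2CCN(c3cccc4ccccc34)CC2)c1C(=O)c1ccc(Cl)cc1` carries naphthalen-1-yl instead, and in this assay compound 2 gives 8.7%. Compound 2 therefore stands highest of the two numbers shown, with compound 1 as its only neighbour; the step of a number 20.7 percentage points higher from compound 1 to compound 2 (beyond the scatter) shows that an aryl swap at this position can move the read-out modestly.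

Compound 3 `Nc1scc(CN2CCN(c3ccccc3Cl)CC2)c1C(=O)c1ccc(Cl)cc1` differs from compound 2 in one place: 2-chlorophenyl in place of naphthalen-1-yl on an amine nitrogen in a ring. Among the compounds with values here, the single relevant step is a number 20.7 percentage points higher from compound 1 to compound 2 (beyond the scatter), so an aryl change here is expected to shift the number by a modest amount, though its direction for 2-chlorophenyl is not fixed by two points. Compound 3 is estimated at 0%, within -20% to 20%, which would mean an expected step of a number 8.7 percentage points lower from compound 2 to compound 3 (within the scatter).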

Compound 3, a percentage reported as activity, at one concentration (the size of the read-out at that concentration, not a potency): -2.1%
Beside the measured number, compound 3's estimate is 2.1 percentage points above it; the measured number falls inside the stated range.
By their numbers in this assay, from the lowest: compounds 1 and 3 (each within the scatter of the next); then compound 2.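

In this assay, replacing the two-ring naphthalen-1-yl with the one-ring 2-chlorophenyl on the same ring nitrogen gives a step beyond the scatter (a number 10.8 percentage points lower from compound 2 to compound 3 (beyond the scatter)). The two substituted phenyl groups, by contrast, cannot be told apart at this position (a number 9.9 percentage points higher from compound 1 to compound 3 (within the scatter)), so among these three compounds naphthalen-1-yl alone stands apart, and no compound here goes against that. No supporting measurement accounts for either step.

Going by these compounds, whether the second aromatic ring of naphthalen-1-yl sets the gap stays open, and a plain phenyl or a cyclohexyl on that nitrogen would bear on it. A 4-chlorophenyl would likewise show whether the place of the chlorine on the ring matters.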